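The source may hold more compounds than are shown below. What is called first, only, known or untested is meant among the compounds shown, and "the series" means these compounds.

Measured so far:
compound 1, `C#CCCOC(=O)/C=C(C)/C=C/CC(C)CCCC(C)(C)OC`: 5.2
compound 2, `CCNC(=O)OC(C)(C)CCCC(C)C/C=C/C(C)=C/C(=O)OCC`: 5.65

In a physicochemical assay for lipophilicity (on this read-out lower numbers stand for lower lipophilicity and higher numbers for higher lipophilicity), compound 1 gives 5.2, the lower of the two numbers recorded; compound 2 gives 5.65, a higher value. Going by the values given here, no pair of measured compounds separated by a single change is available, so the expectation for the next compound rests on the change alone. Compound 3, `CCNC(=O)/C=C(C)/C=C/CC(C)CCCC(C)(C)OC`, differs from compound 1 in one place: ethylamino in place of (but-3-yn-1-yl)oxy on a carbonyl carbon. The expected step of a number 1.50 log units lower from compound 1 to compound 3 (beyond the scatter) runs downward and well beyond the scatter in this assay. For compound 3 the estimate is 3.7, expected to lie between 3.1 and 4.3.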

Compound 3, partition coefficient: 4.04
Beside the measured number, compound 3's estimate is 0.34 log units below it; measured number inside the range.
By their numbers in this assay, from the lowest: compound 3; then compound 1; then compound 2.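

In this assay, going by these compounds alone, ethylamino in place of (but-3-yn-1-yl)oxy on a carbonyl carbon gives a number 1.16 log units lower from compound 1 to compound 3 (beyond the scatter) and provides the first single-place comparison. The read-out therefore responds strongly to the group at this position. However, the change alters the linking atom, the triple bond, the hydrogen-bond count and the heavy-atom count together, and nothing available bears on the cause of the step. Which of these differences carries the step stays open. An ethoxy group or a (but-3-yn-1-yl)amino group on the same carbonyl carbon would help separate them.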